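Replacing Phenyl with Naphthalen-1-yl on a Shared Core

The compounds below may be only part of what the source reports. "The series", "measured", "known", "first", "only" and "open" are said of these compounds alone.

Measured so far:
compound 1 `c1ccc(-c2ccc3c(NCCCNCc4ccco4)ccnc3c2)cc1`, 9.47 in a physicochemical assay for acid dissociation
compound 2 `CC(C)(C)c1ccc(Oc2ccc3c(NCCCNCc4ccco4)ccnc3c2)cc1`, 9.28 in this assay
compound 3 `COc1cccc(CNCCCNc2ccnc3cc(-c4ccccc4)ccc23)c1O`, 9.47 in this assay

Compound 1 stands level with compound 3 at the digits printed, and the two together are the highest of the three numbers; compound 2 lies lower by an amount that is within the scatter, so the three values cannot be ranked.

Compound 4 `c1coc(CNCCCNc2ccnc3cc(-c4cccc5ccccc45)ccc23)c1` differs from compound 1 in one place: naphthalen-1-yl in place of phenyl on an aromatic carbon.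

Going by the values given here, only one step between measured compounds is available, and it sits elsewhere: no change at the digits printed from compound 1 to compound 3 (within the scatter). That exchange at the chain end left the number unchanged. Among the compounds with values here, the other comparison, compound 1 against compound 2, shows two values within the scatter of each other, and no step is given for it. Within the data shown here, none of the measured compounds alters the group on the aromatic carbon of the core, so no direct precedent exists for the change to compound 4. With every exchange seen so far leaving this assay essentially unchanged, no step beyond the scatter is expected here either.

Compound 4 is therefore estimated at 9.45, with a range from 9.15 to 9.75, an expected step of a number 0.02 log units lower from compound 1 to compound 4 (within the scatter).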

Compound 4, acid dissociation constant: 9.47
The estimate for compound 4 lay 0.02 log units below the measured number; low and high end bracket the measured number.
By their numbers in this assay, from the lowest: compounds 2, 1, 3 and 4 (each within the scatter of the next).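

In this assay, putting naphthalen-1-yl in place of phenyl on an aromatic carbon of the shared core gives no change at the digits printed from compound 1 to compound 4 (within the scatter). Going by these compounds alone, this is the first step that shows what happens at this position, since the only earlier step, no change at the digits printed from compound 1 to compound 3 (within the scatter), concerned the group at the chain end; here the substituent grows from 6 to 10 heavy atoms and from one six-membered aromatic ring to 2, with no difference beyond the scatter. No measurement shown here accounts for this result, so the reason for it remains unknown.

Phenyl and naphthalen-1-yl both contain only carbon, have no hydrogen-bond donors or acceptors and carry no net charge, so it remains open whether an amine or a carboxylic acid on this aromatic carbon would also leave the number within the scatter. Going by these compounds, it also remains open whether naphthalen-1-yl would give the same result with 2-hydroxy-3-methoxyphenyl in place of furan-2-yl on the chain, the combination of the changes seen in compound 3 and compound 4.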